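A Hydroxy Group Replaces a Methyl on the Amide Chain

A few compounds are considered here, and "the series" means these few. Any claim that something is new, unique, unknown or untested is made for them only; others in the source may bear on it.

Among the compounds with values here, compound 1 `CCC(=O)N(Cc1ccc(OC)c(O)c1)c1cc(OC)c(OC)c(OC)c1` gives 50 nM in a functional assay on MGC-803 cells (Homo sapiens) for inhibition, read by MTT assay, with a stated time of 48 h (on this read-out higher numbers stand for weaker inhibition and lower numbers for stronger inhibition), the lowest of the two numbers known so far. Compound 2 `C/C=C/C(=O)N(Cc1cc(OC)c(OC)c(OC)c1)c1ccc(OC)c(O)c1` gives 6150 nM in this assay, a far higher number that lies beyond the usual scatter. Compound 3 `COc1ccc(CN(C(=O)CO)c2cc(OC)c(OC)c(OC)c2)cc1O` is compound 1 with a single change: hydroxy in place of methyl on a saturated chain carbon bound to a carbonyl carbon. Within the data shown here, no measured pair shows this exact change, so its effect is not known from the data. A step of moderate size toward weaker inhibition is expected, a 3.0-fold higher number from compound 1 to compound 3 (0.48 log units; beyond the scatter). Compound 3 is estimated at 150 nM, with a range from 40 nM to 800 nM.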

Compound 3, half-maximal inhibitory concentration: 160 nM
For compound 3 the middle estimate is 1.1-fold (0.03 log units) below the measured one; the measured number falls inside the stated range.
By their numbers in this assay, from the lowest: compound 1; then compound 3; then compound 2.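

Putting hydroxy in place of methyl on this saturated chain carbon bound to a carbonyl carbon gives a 3.2-fold higher number from compound 1 to compound 3 (0.51 log units; beyond the scatter) in this assay, a modest loss of inhibition. The position therefore responds to this single-atom swap, yet compound 3 still reads 160 nM, so inhibition is weakened rather than lost. Nothing measured here explains why the number rises. Still open, going by these compounds, is how an amine, a carboxylic acid or a longer chain at this place would compare with methyl and hydroxy.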